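Methoxy to Hydroxy on the Shared Core

This account rests on a few compounds, and the source may have more. Where it says the series, first, only, none or still open, it means among the compounds named here.

Compound 2 `COc1ccc(/C=C2/N=C(c3ccccc3)N(c3ccc4oc(-c5ccccc5)cc(=O)c4c3)C2=O)cc1` and compound 1 `O=C1/C(=C\c2ccccc2)N=C(c2ccccc2)N1c1ccc2oc(-c3ccccc3)cc(=O)c2c1` share one core and differ at a single aromatic carbon. In a functional assay on HeLa cells (Homo sapiens) for inhibition, read by sulforhodamine B assay (on this read-out lower numbers stand for stronger inhibition and higher numbers for weaker inhibition), compound 1 gives 20.9 ug/mL, and compound 2 gives 17.6 ug/mL. The step of a 1.2-fold lower number from compound 1 to compound 2 (0.07 log units; within the scatter) left the read-out essentially unchanged; compound 2 has the lower of the two numbers, yet the two values lie within the scatter of each other, so no order between them can be drawn.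

Compound 3 `O=C1/C(=C\c2ccc(O)cc2)N=C(c2ccccc2)N1c1ccc2oc(-c3ccccc3)cc(=O)c2c1` differs from compound 2 as follows: hydrogen in place of methyl on an oxygen on an aromatic ring. For the measured compounds named here, the only measured step that bears on this site is the one from hydrogen to methoxy, which stayed within the scatter, so a similarly small move is expected here. Compound 3 is therefore estimated to give 18 ug/mL in this assay, with an expected range from 9 ug/mL to 36 ug/mL. The expected step of a 1.0-fold higher number from compound 2 to compound 3 (0.01 log units; within the scatter) is estimated to stay within the scatter.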

Compound 3, half-maximal inhibitory concentration: 18.9 ug/mL
Estimate against measurement, compound 3: 1.1-fold (0.02 log units) below, within the range that was stated.
By their numbers in this assay, from the lowest: compounds 2, 3 and 1 (each within the scatter of the next).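

The exchange of methoxy for hydroxy on this aromatic ring stays within the scatter in this assay (a 1.1-fold higher number from compound 2 to compound 3 (0.03 log units; within the scatter)), and hydroxy in place of hydrogen on the aromatic carbon does the same (a 1.1-fold lower number from compound 1 to compound 3 (0.04 log units; within the scatter)). Hydrogen, methoxy and hydroxy have now all been read at this one site, and no order can be drawn among compound 1, compound 2 and compound 3, whereas the earlier pair covered only hydrogen and methoxy. No supporting data are available that could account for this flat reading.

The compounds shown leave open whether an amine, a carboxylic acid or a longer alkoxy chain at this site would move the number beyond the scatter. They also leave open whether a change elsewhere on the shared core would do so.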